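Series notes: amine replacement on the core of compound 2

The compounds below may be only part of what the source reports. "The series", "measured", "known", "first", "only" and "open" are said of these compounds alone.

Compound 1 `Nc1nc(Nc2ccc(OC(F)(F)F)cc2)c2nc[nH]c2n1` gives 20000 nM in an assay on isolated protein for inhibition of interferon-induced, double-stranded RNA-activated protein kinase (Homo sapiens), read by luminescence, with a stated time of 10 min; a higher number here means a weaker inhibitor, a lower number a stronger inhibitor. Compound 2 `Cc1[nH]c2ccccc2c1-c1ccnc(NC(CO)C(C)C)n1` gives 50000 nM in this assay, the higher of the two numbers, and its gap to compound 1 lies beyond the scatter. Compound 3 `Cc1[nH]c2ccccc2c1-c1ccnc(Nc2ccc(F)cc2)n1` differs from compound 2 by 4-fluorophenyl in place of 1-(hydroxymethyl)-2-methylpropyl on a nitrogen on an aromatic ring. For the measured compounds named here, no such step has been measured here. The step from compound 2 to compound 3 is expected to lower the number, by about a 5.0-fold lower number from compound 2 to compound 3 (0.70 log units; beyond the scatter), since the arylamino compound 1 gives 20000 nM. Compound 3 is estimated at 10000 nM, within 2000 nM to 50000 nM.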

Compound 3, half-maximal inhibitory concentration: 150 nM
Estimate against measurement, compound 3: 67-fold (1.82 log units) above; measured number below the stated range.
By their numbers in this assay, from the lowest: compound 3; then compound 1; then compound 2.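

On the nitrogen on an aromatic ring, (4-fluorophenyl)amino in place of (1-(hydroxymethyl)-2-methylpropyl)amino gives a 330-fold lower number from compound 2 to compound 3 (2.52 log units; beyond the scatter), the first step readable in this series. In this assay this substituent therefore has a large bearing on the number, and the change favours 4-fluorophenyl over 1-(hydroxymethyl)-2-methylpropyl. Nothing shown here accounts for the size of this step.

The compounds shown leave open what the fluorine itself contributes, which a plain phenyl would test. A cyclohexyl group on the same nitrogen would separate the effect of a ring from that of an aromatic ring.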